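A few compounds are considered here, and "the series" means these few. Any claim that something is new, unique, unknown or untested is made for them only; others in the source may bear on it.

Measured compounds:
- compound 1 `CCCS(=O)(=O)c1ccc(C)c(C#Cc2cc(Cl)ccc2OC(C)C(=O)O)c1`: 1.2 nM
- compound 2 `O=C(O)COc1ccc(Cl)cc1C#Cc1ccccc1Cl`: 28 nM

In an assay on CHO cells for displacement of a labelled ligand from prostaglandin D2 receptor 2 (Homo sapiens), read by scintillation counting (on this read-out lower numbers stand for stronger inhibition and higher numbers for weaker inhibition), compound 1 gives 1.2 nM, the lowest of the two numbers recorded. Compound 2 gives 28 nM, a much higher number, and the gap between the two lies well beyond the scatter of repeated measurements. Going by the values given here, the two measured compounds differ in several places at once, so no single-point step between them can be read.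

Compound 3 `CCCS(=O)(=O)c1ccc(C)c(C#Cc2cc(Cl)ccc2OC(CC)C(=O)O)c1` is the next compound to be run in this assay. It differs from compound 1 in one place only: methyl in place of hydrogen on a saturated chain carbon, two bonds along the chain from a carbonyl carbon and an oxygen on an aromatic ring. Among the compounds with values here, no measured pair isolates this kind of change, so there is no direct precedent to lean on. Given the size of the change, the step is expected to be small, within the scatter or close to it, in either direction; the expected step from compound 1 to compound 3 is a 1.3-fold higher number from compound 1 to compound 3 (0.10 log units; within the scatter). For compound 3 the expected value in this assay is 1.5 nM, with a range from 0.5 nM to 5 nM.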

Compound 3, inhibition constant: 30 nM
Beside the measured number, compound 3's estimate is 20-fold (1.30 log units) below it; measured number outside the range, above it.
By their numbers in this assay, from the lowest: compound 1; then compounds 2 and 3 (each within the scatter of the next).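

In this assay, going by these compounds alone, going from 1-carboxyethoxy to 1-carboxypropoxy gives a 25-fold higher number from compound 1 to compound 3 (1.40 log units; beyond the scatter) for the addition of a single methyl, the first single-point reading. This saturated chain carbon, two bonds along the chain from a carbonyl carbon and an oxygen on an aromatic ring, is therefore a sensitive position on the core of compound 1, where the smaller 1-carboxyethoxy is clearly favoured. Nothing at hand accounts for the size of this step.

The compounds shown leave open how a carboxymethoxy group, carrying only hydrogen at this carbon, would read on the core of compound 1, and so whether the methyl of compound 1 itself contributes. They also leave open whether a longer chain such as propyl, or a ring such as cyclopropyl, at this carbon would follow the same direction.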